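From compound 2 to its 3-fluorophenyl counterpart

A few compounds are considered here, and "the series" means these few. Any claim that something is new, unique, unknown or untested is made for them only; others in the source may bear on it.

For the measured compounds named here, in a functional assay on HL-60 cells (Homo sapiens) for inhibition, read by MTT assay, with a stated time of 72 h (a lower number here means a stronger inhibitor, a higher number a weaker inhibitor), compound 2 (`Cc1nc(-c2ccccc2)c(C(=O)N2CCN(c3cccc(Cl)c3)CC2)o1`) gives 39.2 nM and is the only one of three measured compounds with a number to its name. In this assay compound 1 (`COc1cccc(N2CCN(C(=O)c3oc(C(F)(F)F)nc3-c3cccc(F)c3)CC2)c1`) gives "not active" (no number reported) and no value can be set beside that of compound 2. In this assay compound 3 (`Cc1nc(-c2ccc(Cl)cc2)c(C(=O)N2CCN(c3cccc(C(=O)C(C)C)c3)CC2)o1`) gives "not active" (no number reported) and so adds no second number either.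

Compound 4 (`Cc1nc(-c2cccc(F)c2)c(C(=O)N2CCN(c3cccc(Cl)c3)CC2)o1`) has yet to be measured. Its difference from compound 2 is small: fluoro in place of hydrogen on an aromatic carbon (fluoro in place of hydrogen on an aromatic carbon, which turns phenyl into 3-fluorophenyl). No two measured compounds differ in a single place, so the data offer no direct precedent for this change and no reason to favour either direction. The expectation therefore rests on the value of compound 2 (39.2 nM) and on how little the structure changes. The estimate is a 1.1-fold higher number from compound 2 to compound 4 (0.06 log units; within the scatter) in this assay and thus no shift beyond the usual scatter, although a result without a number remains possible. Compound 4 is estimated at 45 nM with an expected range from 12 nM to 160 nM (should a number be reported at all).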

Compound 4, half-maximal inhibitory concentration: 33.7 nM
Compound 4: the middle estimate sits 1.3-fold (0.13 log units) above what was measured; the range from low to high includes it.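

In this assay, for the compounds shown here, the change from phenyl to 3-fluorophenyl gives a 1.2-fold lower number from compound 2 to compound 4 (0.07 log units; within the scatter), the first step between two compounds that differ in one place. It shows that, on this pair, a fluoro on an aromatic carbon meta to a large group leaves the read-out within the scatter, and that the compound keeps a reported number, unlike compound 1 and compound 3. No measurement bears on why the value holds at this position, so the step records a tolerated change and gives no explanation for it.

This is a single pair with a single small group, so the compounds shown leave open whether a larger or very different group at the same place, such as a nitrile, a carboxylic acid or an amine, would keep a number in this assay. They also leave open which feature goes with the lack of a number for compound 1 and compound 3, as each differs from compound 2 in more than one place.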